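Chloro to fluoro on the aryl ring of compound 3

The source may hold more compounds than are shown below. What is called first, only, known or untested is meant among the compounds shown, and "the series" means these compounds.

Three compounds of the series carry the same acetylated cysteine-derived core. Compound 1 `CC(=O)N[C@@H](CSC(=O)NCc1ccc(Cl)cc1)C(=O)O` and compound 2 `COc1ccccc1CNC(=O)SC[C@H](NC(C)=O)C(=O)O` have no result: in a functional assay on SK-MEL-2 cells (Homo sapiens) for cytotoxicity, read by MTT assay, with a stated time of 6 days (a lower number here means a stronger inhibitor, a higher number a weaker inhibitor), compound 1 gives "not determined" (no result reported) and compound 2 gives "not determined" (no result reported). Among the measured compounds shown here, compound 3 `CC(=O)N[C@@H](CSC(=O)Nc1ccc(Cl)cc1)C(=O)O` is therefore the only member with a number, and in this assay compound 3 gives 8 nM, a low value that places it as a strong inhibitor on the single figure available; no comparison with another measured compound can be drawn from these data.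

Compound 4 `CC(=O)N[C@@H](CSC(=O)Nc1ccc(F)cc1)C(=O)O` is the next entry and is yet to be measured in this assay. It differs from compound 3 by one atom on the aromatic ring (fluoro in place of chloro on an aromatic carbon). For the measured compounds named here, no measured pair shows a step of this kind, so the size of the effect rests on the change itself. A small loss of potency, possibly within the usual scatter, is expected, and the estimated step of a 2.5-fold higher number from compound 3 to compound 4 (0.40 log units; beyond the scatter) reflects this. Compound 4 is expected to give 20 nM in this assay, with a range from 5 nM to 80 nM.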

Compound 4, half-maximal inhibitory concentration in the SK-MEL-2 assay: 430 nM
For compound 4 the middle estimate is 22-fold (1.33 log units) below the measured one; measured number outside the range, above it.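

Among the compounds shown here, in the SK-MEL-2 assay the exchange of chloro for fluoro, on an aromatic carbon para to a large group, gives a 54-fold higher number from compound 3 to compound 4 (1.73 log units; beyond the scatter), the first readable step, so this position is highly sensitive to the identity of a single atom. In a physicochemical assay for solubility, in phosphate buffer, at pH 7.4 (a lower number here means a less soluble compound, a higher number a more soluble compound), compound 3 gives 26 ug/mL and compound 4 gives 26 ug/mL, so the large potency step is not accompanied by any difference in solubility. Nothing in the data shown accounts for the size of this step.

Going by these compounds, with only chloro and fluoro at this position, two points cannot define a trend, and it remains open how bromo or methyl there would compare with compound 3. Also open, on these data alone, is whether a methyl ester in place of the carboxylic acid would retain the potency of compound 3.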